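This account rests on a few compounds, and the source may have more. Where it says the series, first, only, none or still open, it means among the compounds named here.

Compound 1 `COc1cccc(CNCCCNc2ccnc3cc(C4CCCCC4)ccc23)c1O` is the starting point. Among the measured compounds shown here, in an ADME assay on HepG2 cells (Homo sapiens) for cytotoxicity, read by luminescence, CellTiter-Glo and ATP content, with a stated time of 72 h (a lower number here means that less compound is needed, a higher number that more compound is needed for the effect), compound 1 gives 1080 nM, the lowest of the three numbers measured so far. Compound 2 `COc1ccc(F)cc1CNCCCNc1ccnc2cc(C3CCCCC3)ccc12` differs from it only in the group on the saturated chain carbon bound to an amine nitrogen, and in this assay compound 2 gives 2290 nM. That step is a 2.1-fold higher number from compound 1 to compound 2 (0.33 log units; beyond the scatter). Compound 3 `COc1ccc(F)cc1CNCCCNc1ccnc2cc(Oc3cccc(N(C)C)c3)ccc12` keeps the group of compound 2 on that chain carbon and changes the group on an aromatic carbon instead; in this assay compound 3 gives 3300 nM. That step is a 1.4-fold higher number from compound 2 to compound 3 (0.16 log units; within the scatter).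

Compound 4 `COc1cccc(CNCCCNc2ccnc3cc(CCc4ccccc4)ccc23)c1O` has not yet been measured. It differs from compound 1 in one place: phenethyl in place of cyclohexyl on an aromatic carbon. For the measured compounds named here, the only measured step at that same aromatic carbon is the one where cyclohexyl was exchanged for a different group, which moved the number only within the scatter, a 1.4-fold higher number from compound 2 to compound 3 (0.16 log units; within the scatter). Going by the values given here, no measured compound carries a phenethyl there, so the evidence is thin. For compound 4 the step expected is a 1.2-fold higher number from compound 1 to compound 4 (0.08 log units; within the scatter), which would stay within the scatter. Compound 4 is therefore estimated to give 1300 nM in this assay, with a likely range from 500 nM to 3500 nM.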

Compound 4, half-maximal effective concentration: 6800 nM
For compound 4 the middle estimate is 5.2-fold (0.72 log units) below the measured one; measured number outside the range, above it.
By their numbers in this assay, from the lowest: compound 1; then compounds 2 and 3 (each within the scatter of the next); then compound 4.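

At this aromatic carbon, the exchange of cyclohexyl for phenethyl in this assay gives the largest step among these compounds (a 6.3-fold higher number from compound 1 to compound 4 (0.80 log units; beyond the scatter)), so more compound is needed for the effect. The earlier change at this carbon, made with a different group on the chain and a different incoming group, stayed within the scatter (a 1.4-fold higher number from compound 2 to compound 3 (0.16 log units; within the scatter)), so this position is not indifferent to what it carries, and the outcome depends on the particular change. Phenethyl has 8 heavy atoms against 6 in cyclohexyl and an aromatic ring in place of a non-aromatic one, but no measurement at hand explains why this exchange raises the number.

From the compounds shown here alone, it remains open whether the rise follows the two-carbon link or the aromatic ring, and a 2-cyclohexylethyl group or a plain phenyl at this carbon would help to separate the two. Going by these compounds, it is also open whether phenethyl would have a similar effect alongside the 5-fluoro-2-methoxyphenyl group of compound 2.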